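The source may report more compounds than this note shows. Statements on the series, on what has been measured and on what is new or still open speak of the compounds shown alone.

Compound 2 `CCNC(=S)N/N=C1\C(=O)Nc2ccccc21` is the point of departure. In an ADME assay on RD cells (Homo sapiens) for cytotoxicity (on this read-out lower numbers stand for higher toxicity in this test and higher numbers for lower toxicity in this test), compound 2 gives > 25000 nM, which is a limit of the assay rather than a measured number. Among the compounds with values here, the only other compound with a result is compound 1 `Cc1ccccc1NC(=S)N/N=C1\C(=O)Nc2ccccc21`. In this assay compound 1 gives > 25000 nM, again a limit. Within the data shown here, the single measured step, a step that the two limits leave unreadable from compound 1 to compound 2, is therefore of a size that cannot be read. Compound 3 `O=C1Nc2ccccc2/C1=N/NC(=S)Nc1cccc(Cl)c1` has not yet been tested. It differs from compound 2 by 3-chlorophenyl in place of ethyl on an amide-type nitrogen. Among the measured compounds shown here, no measured step bears readably on this change; all that is known is that both measured compounds sit at the limit of > 25000 nM in this assay, at which 2 of the 2 values shown sit. Compound 3 is expected to sit there too, so that a step that the limit leaves unreadable from compound 2 to compound 3 is estimated as no step beyond the scatter. The estimate for compound 3 in this assay is 40000 nM, with a range from 15000 nM to 150000 nM.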

Compound 3, half-maximal cytotoxic concentration: > 25000 nM
Compound 3: no number, only a limit; the forecaster's own chance of this, stated with the estimate: 85%; the middle value lies beyond the limit too.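

Compound 3 also gives only a limit, so its steps from compound 1 and compound 2 cannot be read: the limit of > 25000 nM in this assay, at which 3 of the 3 values shown sit.

The compounds shown leave open how much cytotoxic concentration separates ethyl, 2-methylphenyl and 3-chlorophenyl on the amide-type nitrogen in this assay.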